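Isopropyl for propyl on the pyrazine-bearing chalcone core

A few compounds are considered here, and "the series" means these few. Any claim that something is new, unique, unknown or untested is made for them only; others in the source may bear on it.

Measured so far in a functional assay on the whole organism for inhibition, with Spinacia oleracea as the target, read by spectrophotometry, with a stated time of 4 h; a higher number here means a weaker inhibitor, a lower number a stronger inhibitor:
- Compound 1, `CC(C)(C)c1cnc(C(=O)Nc2cccc(O)c2)cn1`: compound 1 gives 478000 nM.
- Compound 2, `CCCc1cnc(C(=O)/C=C/c2ccc(O)cc2)cn1`: compound 2 gives 399000 nM.
- Compound 3, `CC(C)(C)c1ncc(C(=O)Nc2cc(O)cc(Cl)c2)nc1Cl`: compound 3 gives 105000 nM.

Compound 2 sits among the higher numbers of this small set. Its value and that of compound 1 lie within the scatter of each other, so no order between the two can be read. Compound 3 gives a lower number than compound 2, and that gap is beyond the scatter; compound 3 differs from compound 2 in more than one place, so the gap is not assigned to any single change.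

Compound 4, `CC(C)c1cnc(C(=O)/C=C/c2ccc(O)cc2)cn1`, is the next member. It differs from compound 2 by isopropyl in place of propyl on an aromatic carbon, the two compounds holding the same atoms joined differently. Among the compounds with values here, no measured pair isolates a change of this kind, so the expectation rests on compound 2 alone. For so small a rearrangement of a short chain, a step no larger than the scatter is expected in either direction, and the value of compound 4 in this assay is estimated at 400000 nM, within 150000 nM to 1000000 nM. The step this implies, a 1.0-fold higher number from compound 2 to compound 4 (0.00 log units; within the scatter), is expected to stay within the scatter.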

Compound 4, half-maximal inhibitory concentration: 315000 nM
Compound 4: the middle estimate sits 1.3-fold (0.10 log units) above what was measured, within the range that was stated.
By their numbers in this assay, from the lowest: compound 3; then compounds 4, 2 and 1 (each within the scatter of the next).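

In this assay, a 1.3-fold lower number from compound 2 to compound 4 (0.10 log units; within the scatter) gives the series its first comparison that differs in one place only. On this aromatic carbon, next to the ring nitrogen and para to a large group, isopropyl in place of propyl leaves a difference within the scatter, so compound 2 and compound 4 cannot be ordered. With the same three carbons rearranged, this pair gives no sign that the choice between the two chains matters in this assay, and nothing on hand bears on any cause.

Going by these compounds, whether a longer chain such as hexyl, or an amine, at this position would move the number beyond the scatter remains open. Also open, on these data alone, is whether the same exchange of propyl and isopropyl would behave alike on the core of compound 1.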